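Replacing an amide arm with a hydroxyethoxy benzyl group

The source may report more compounds than this note shows. Statements on the series, on what has been measured and on what is new or still open speak of the compounds shown alone.

In an assay on isolated protein for agonist activity at Bile acid receptor (Homo sapiens), read by FRET (on this read-out higher numbers stand for larger maximal responses and lower numbers for smaller maximal responses), compound 1 `CC(C)c1onc(-c2c(Cl)cccc2Cl)c1COc1ccc(N(C)C(=O)c2ccc(C(=O)O)cc2)c(C(F)(F)F)n1` gives 101% and stands highest of the two measured values. Within the data shown here, its nearest neighbour, compound 2 `CC(C)c1onc(-c2c(Cl)cccc2Cl)c1COc1ccc(N(C)Cc2ccc(OCC(=O)O)cc2)c(C(F)(F)F)n1`, gives 90% in this assay; the single measured step, a number 11 percentage points lower from compound 1 to compound 2 (beyond the scatter), exchanged the same group on the ring nitrogen. Compound 3 `CC(C)c1onc(-c2c(Cl)cccc2Cl)c1COc1ccc(N(C)Cc2ccc(OCCO)cc2)c(C(F)(F)F)n1` differs from compound 1 by 4-(2-hydroxyethoxy)benzyl in place of (4-carboxyphenyl)carbonyl on a nitrogen on an aromatic ring. Among the measured compounds shown here, since the one comparable step was modest and downward, a step of similar size is expected from compound 1 to compound 3 in this assay, a number 15 percentage points lower from compound 1 to compound 3 (beyond the scatter). Compound 3 is therefore estimated at 86%, within 70% to 102%.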

Compound 3, largest response reached (reported as efficacy), in percent of the reference or control that the assay uses: 87%
Beside the measured number, compound 3's estimate is 1 percentage points below it, and the stated range covers the measured number.
By their numbers in this assay, from the lowest: compounds 3 and 2 (each within the scatter of the next); then compound 1.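

In this assay, the neutral-count change at this nitrogen, 4-(2-hydroxyethoxy)benzyl in place of (4-carboxyphenyl)carbonyl, gives a number 14 percentage points lower from compound 1 to compound 3 (beyond the scatter) and so remains a modest loss. Hydroxymethyl in place of carboxy on the saturated chain carbon gives a number 3 percentage points lower from compound 2 to compound 3 (within the scatter) and so shows that, on this benzyl group, the carboxy group can be exchanged without a readable change. No evidence at hand accounts for the size of either step. The compounds shown leave open how an amine or a longer chain at the end of this benzyl group would read.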